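Thiophene carbonyl in place of sulfonyl: outlook for compound 4

A few compounds are considered here, and "the series" means these few. Any claim that something is new, unique, unknown or untested is made for them only; others in the source may bear on it.

Measured so far:
compound 1, `CCN1CCN(c2cccc3c2CN([C@H](CCCNC(=O)c2c(C)n[nH]c2C)c2ccc(OC)c(OC)c2)C3=O)CC1`, gives 11 nM in an assay on RMS13 cells for displacement of a labelled ligand from Urotensin-2 receptor (Homo sapiens), read by scintillation proximity assay; on this read-out lower numbers stand for stronger inhibition and higher numbers for weaker inhibition.
compound 2, `CCN1CCN(c2cccc3c2CN([C@H](CCCNS(=O)(=O)c2c[nH]cn2)c2ccc(OC)c(OC)c2)C3=O)CC1`, gives 25 nM in this assay.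
compound 3, `CCN1CCN(c2cccc3c2CN([C@H](CCCN(C)S(=O)(=O)c2cccs2)c2ccc(OC)c(OC)c2)C3=O)CC1`, reaches only the limit of this assay, < 5 nM.

The value of compound 3 is a limit, not a number; (the limit of < 5 nM in this assay, at which 1 of the 3 values shown sits). It marks the floor of the three values shown, so compound 3 stands at or beyond the low end of the set. Compound 4, `CCN1CCN(c2cccc3c2CN([C@H](CCCNC(=O)c2cccs2)c2ccc(OC)c(OC)c2)C3=O)CC1`, carries ((thiophen-2-yl)carbonyl)amino in place of methyl((thiophen-2-yl)sulfonyl)amino on a saturated chain carbon, four bonds along the chain from an amide-type nitrogen in a ring and an aromatic carbon. Among the compounds with values here, no measured step moves exactly this way, but three bear on it. a 2.3-fold higher number from compound 1 to compound 2 (0.36 log units; beyond the scatter) ran counter to the direction compound 4 requires. an at least 2.2-fold lower number from compound 1 to compound 3 (0.34 log units; beyond the scatter) and an at least 5.0-fold lower number from compound 2 to compound 3 (0.69 log units; beyond the scatter) both favoured the methyl((thiophen-2-yl)sulfonyl)amino group now leaving. Compound 4 is an amide like compound 1, with a thiophene in place of the (3,5-dimethyl-1H-pyrazol-4-yl)carbonyl, so a return toward the range of compound 1 is expected; the exact size from compound 3 cannot be fixed, compound 3 being a limit. A modest rise in this assay is expected, an at least 2.0-fold higher number from compound 3 to compound 4 (0.30 log units; that floor lies within the scatter). Compound 4 is estimated at 10 nM, range 3 nM to 30 nM.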

Compound 4, inhibition constant: 18 nM
For compound 4 the middle estimate is 1.8-fold (0.26 log units) below the measured one; measured number inside the range.
By their numbers in this assay, from the lowest: compounds 1, 4 and 2 (each within the scatter of the next, the first and the last beyond it). At a limit, below all of these: compound 3.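

Keeping the thiophen-2-yl group does not keep the low number of compound 3: ((thiophen-2-yl)carbonyl)amino in place of methyl((thiophen-2-yl)sulfonyl)amino gives an at least 3.6-fold higher number from compound 3 to compound 4 (0.55 log units; beyond the scatter). Compound 3 stands at a limit: the limit of < 5 nM in this assay, at which 1 of the 4 values shown sits. With the carbonyl kept, thiophen-2-yl and 3,5-dimethyl-1H-pyrazol-4-yl are not told apart, at a 1.6-fold higher number from compound 1 to compound 4 (0.21 log units; within the scatter), and (thiophen-2-yl)carbonyl and (1H-imidazol-4-yl)sulfonyl on the amine nitrogen are not told apart either, at a 1.4-fold lower number from compound 2 to compound 4 (0.14 log units; within the scatter).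

Going by these compounds, the step from compound 3 changes the sulfonyl to a carbonyl and removes the methyl on the nitrogen together, so the share of each remains open. A methyl((thiophen-2-yl)carbonyl)amino or a ((thiophen-2-yl)sulfonyl)amino group at this place, on the same saturated chain carbon, would separate the two.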